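Sulfamoyl for methylpiperazinyl on the anilino ring

This account rests on a few compounds, and the source may have more. Where it says the series, first, only, none or still open, it means among the compounds named here.

Measured so far in a functional assay on HeLa cells (Homo sapiens) for antiproliferative activity, read by MTT assay; on this read-out lower numbers stand for stronger inhibition and higher numbers for weaker inhibition:
compound 1 `NS(=O)(=O)c1ccc(Nc2ncc(/N=C/c3ccccc3)c(NC3CCCC3)n2)cc1` — 15600 nM
compound 2 `CC(C)Nc1nc(Nc2ccc(N3CCN(C)CC3)cc2)ncc1/N=C/c1ccccc1` — > 100000 nM
compound 3 `CC(C)Nc1nc(Nc2ccc(N3CCN(C)CC3)cc2)ncc1/N=C/c1cccs1` — 77100 nM

Compound 2 gives only a limit of the assay in this assay, > 100000 nM; it stands at the limit of > 100000 nM in this assay, at which 1 of the 3 values shown sits. For the measured compounds named here, of the measured steps, only the one from compound 2 to compound 3 is known: an at least 1.2-fold lower number from compound 2 to compound 3 (0.11 log units; that floor lies within the scatter). That step touches the carbon with the double bond to nitrogen, not the anilino ring, and is bounded by the limit of compound 2.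

Compound 4 `CC(C)Nc1nc(Nc2ccc(S(N)(=O)=O)cc2)ncc1/N=C/c1ccccc1` differs from compound 2 as follows: sulfamoyl in place of 4-methylpiperazin-1-yl on an aromatic carbon. Going by the values given here, no measured step covers this exchange directly. Compound 1 carries the same sulfamoyl group on the anilino ring and differs from compound 4 elsewhere. In this assay compound 1 gives 15600 nM. Compound 2, by contrast, gives only a limit of the assay. Set side by side, the two results show that a sulfamoyl-bearing member of the series can sit well below where compound 2 stands.

On this basis compound 4 is expected to come out near the value of compound 1, with the step of an at least 5.0-fold lower number from compound 2 to compound 4 (0.69 log units; beyond the scatter) read as a move away from the limit. The estimate for compound 4 is 20000 nM, with a range from 6000 nM to 70000 nM.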

Compound 4, half-maximal inhibitory concentration: > 100000 nM
Compound 4: no number, only a limit; the forecaster's own chance of this, stated with the estimate: 10%; at least 5.0-fold (0.69 log units) between middle value and limit.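

Sulfamoyl on the anilino ring does not by itself bring a compound off the limit: in this assay compound 4 gives > 100000 nM as a limit of the assay and not a number. The exchange of 4-methylpiperazin-1-yl for sulfamoyl cannot be read, since compound 2 and compound 4 both end at the limit: the limit of > 100000 nM in this assay, at which 2 of the 4 values shown sit. With sulfamoyl held fixed, isopropyl in place of cyclopentyl on the nitrogen gives an at least 6.4-fold higher number from compound 1 to compound 4 (0.80 log units; beyond the scatter) and so, in this pair, the group on that nitrogen decides whether a number can be read at all.

Open, going by these compounds, is whether cyclopentyl on that nitrogen would also bring a compound carrying 4-methylpiperazin-1-yl off the limit, and whether a cyclohexyl group or a longer chain such as n-butyl would go beyond compound 1. Also open, on these data alone, is how a carboxylic acid or a morpholine in place of sulfamoyl would read once the nitrogen carries cyclopentyl, and whether thiophen-2-yl would add anything on a sulfamoyl compound.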